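Benzylamino for bromo on the aminopyridine amide

This account rests on a few compounds, and the source may have more. Where it says the series, first, only, none or still open, it means among the compounds named here.

The two measured compounds share one core, seen in compound 1 `CCOc1ccc(C(=O)Nc2cc(C)cc(C)n2)cc1` and compound 2 `CCCOc1ccc(C(=O)Nc2cccc(Br)n2)cc1`. In an in vitro assay on HEK-tsA201 cells for antagonist activity at Neuronal acetylcholine receptor; alpha3/beta4 (Homo sapiens), read by fluorescence and calcium flux (a lower number here means a stronger inhibitor, a higher number a weaker inhibitor), compound 1 gives 17400 nM. For compound 2 the same assay reports no number but only a limit, > 100000 nM, which is the limit of > 100000 nM in this assay, at which 1 of the 2 values shown sits. Compound 2 therefore stands at the weak end of what this assay can resolve. Among the measured compounds shown here, no step between the two measured compounds is available: compound 1 and compound 2 differ in more than one place.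

Compound 3 `CCCOc1ccc(C(=O)Nc2cccc(NCc3ccccc3)n2)cc1` is the untested member of the set. It arises from compound 2 by the change (benzylamino in place of bromo on an aromatic carbon). Since compound 2 sits at a limit, the size of the step in this assay cannot be anchored to a known value. A change of this extent in the group is expected to move activity beyond the scatter, most likely toward stronger inhibition, but the direction is not secured by any measured pair here.

Compound 3 is estimated at 40000 nM, with a range from 8000 nM to 200000 nM, an expected step of an at least 2.5-fold lower number from compound 2 to compound 3 (0.39 log units; beyond the scatter).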

Compound 3, half-maximal inhibitory concentration: > 100000 nM
Compound 3 ended at the assay's limit (the forecaster's own chance of this, stated with the estimate: 45%); at least 2.5-fold (0.39 log units) between middle value and limit.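

Compound 2 and compound 3 both stand at a limit in this assay, so no step from one to the other can be read: the limit of > 100000 nM in this assay, at which 2 of the 3 values shown sit.

The compounds shown leave open whether benzylamino in place of bromo on an aromatic carbon changes inhibition at all, and if so, in which direction and by how much.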